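The source may hold more compounds than are shown below. What is called first, only, known or untested is meant among the compounds shown, and "the series" means these compounds.

Compound 3 `CCOC(=O)c1c(N)sc(-c2ccccc2)c1-c1cccc(C(F)(F)F)c1` stands second of the three numbers in an assay on CHO-K1 cells for displacement of a labelled ligand from adenosine receptor A1 (Homo sapiens), tested at 10 uM (a higher number here means more inhibition at the concentration tested (going by the name of the read-out), a lower number less inhibition), where compound 3 gives 83.6%. Compound 1 `CCOC(=O)c1c(-c2cccc(C(F)(F)F)c2)csc1N` gives 93%, and the step of a number 9.4 percentage points lower from compound 1 to compound 3 (within the scatter) lies within the scatter, so no order between these two follows. Compound 2 `CC(=O)c1cccc(-c2sc(N)c(C(=O)c3ccccc3)c2-c2cccc(C(F)(F)F)c2)c1` gives 33.1%, beyond the scatter below compound 3. Compound 4 `CCOC(=O)c1c(N)sc(-c2cccc(C(C)=O)c2)c1-c1cccc(C(F)(F)F)c1` differs from compound 3 by acetyl in place of hydrogen on an aromatic carbon. Going by the values given here, no measured step isolates this change; compound 2 also bears an acetyl group but differs from compound 4 elsewhere too, so its low value bears only loosely. A downward step in this assay is expected, estimated as a number 21.6 percentage points lower from compound 3 to compound 4 (beyond the scatter), smaller than the gap to compound 2. Compound 4 is therefore expected to give 62%, between 35% and 85%.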

Compound 4, a percentage reported as inhibition, at one concentration (the size of the read-out at that concentration, not a potency): 68.9%
For compound 4 the middle estimate is 6.9 percentage points below the measured one, and the stated range covers the measured number.
By their numbers in this assay, from the lowest: compound 2; then compound 4; then compounds 3 and 1 (each within the scatter of the next).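

In this assay, the position that took phenyl without a step beyond the scatter responds once that phenyl carries acetyl: a number 14.7 percentage points lower from compound 3 to compound 4 (beyond the scatter), and overall a number 24.1 percentage points lower from compound 1 to compound 4 (beyond the scatter). With the acetyl kept, ethoxy in place of phenyl on the carbonyl carbon gives a number 35.8 percentage points higher from compound 2 to compound 4 (beyond the scatter), a large step, so the low number of compound 2 does not rest on acetyl alone. Nothing at hand explains these steps. Going by these compounds, whether an amine or a carboxylic acid in place of acetyl on this aromatic carbon would give a similar step remains open.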